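A few compounds are considered here, and "the series" means these few. Any claim that something is new, unique, unknown or untested is made for them only; others in the source may bear on it.

Within the data shown here, compound 1 `CC1(OC(=O)N2C[C@H]3COC[C@@H](C2)[C@@H]3Oc2ncnc(Nc3ccccc3F)c2F)CC1` is one of three compounds measured in a functional assay for agonist activity at Glucose-dependent insulinotropic receptor (Mus musculus), read by cAMP accumulation; a lower number here means a smaller maximal response, a higher number a larger maximal response. In this assay compound 1 gives 76%, the lowest of the three numbers. Compound 3 `CC1(OC(=O)N2CC3COCC(C2)C3Oc2ncnc(Nc3ccc(-n4cncn4)cc3F)c2F)CC1` gives 83%, which sits within the usual scatter of the value of compound 1. Compound 2 `CC1(OC(=O)N2CC3COCC(C2)C3Oc2ncnc(Nc3ccc(C#N)cc3Cl)c2F)CCC1` gives 88%, a gap to compound 1 that lies beyond the scatter.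

Compound 4 `CC1(OC(=O)N2C[C@H]3COC[C@@H](C2)[C@@H]3Oc2ncnc(Nc3ccc(C#N)cc3Cl)c2F)CC1` has not been measured. It differs from compound 1 in one place: 2-chloro-4-cyanophenyl in place of 2-fluorophenyl on a nitrogen on an aromatic ring. Among the measured compounds shown here, no step between two measured compounds exactly matches this change. The most relevant comparison is compound 2, which carries the same 2-chloro-4-cyanophenyl group on the nitrogen and gives 88% in this assay, though its stereochemistry is not defined in the way that it is in compound 1 and compound 4.

Compound 4 is therefore expected to show a moderate upward step, a number 9 percentage points higher from compound 1 to compound 4 (within the scatter), in this assay. The estimated value for compound 4 is 85%, with a range from 72% to 96%.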

Compound 4, largest response reached (reported as percent of maximum), in percent of the reference or control that the assay uses: 99%
Estimate against measurement, compound 4: 14 percentage points below; measured number above the stated range.
By their numbers in this assay, from the lowest: compounds 1, 3 and 2 (each within the scatter of the next, the first and the last beyond it); then compound 4.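

In this assay, placing 2-chloro-4-cyanophenyl in place of 2-fluorophenyl on the nitrogen gives a number 23 percentage points higher from compound 1 to compound 4 (beyond the scatter). Among these compounds, this is the first step that can be read at a single place, and it shows that the maximal response on the core of compound 1 moves with the group carried on this nitrogen. Nothing available explains the size of this step or links it to any property of the incoming group.

The step carries the exchange of fluorine for chlorine and the arrival of the nitrile together, and the compounds shown do not separate these two changes. They also leave open how the response would read with a carboxylic acid or an amine in the place of the nitrile.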